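Cytotoxicity notes: trimming the furan from compound 1

The source may report more compounds than this note shows. Statements on the series, on what has been measured and on what is new or still open speak of the compounds shown alone.

Measured so far:
compound 1 `Clc1cccc(Cl)c1Cc1nnc(Nc2ccc(COCc3ccoc3)cc2)o1` gives 21000 nM
compound 2 `Fc1cccc(F)c1Cc1cnc(Nc2ccc(-c3cccnc3)c(Cl)c2)o1` gives 8900 nM
compound 3 `Fc1cccc(F)c1Cc1cnc(Nc2ccc(Oc3cccnc3)c(Br)c2)o1` gives 7500 nM

In an ADME assay on MT2 cells (Homo sapiens) for cytotoxicity, read by MTT assay (on this read-out higher numbers stand for lower toxicity in this test and lower numbers for higher toxicity in this test), compound 1 stands highest of the three numbers; compound 2 and compound 3 both lie lower, each by a margin beyond the usual scatter. Among the compounds with values here, compound 2 and compound 3 share neither core nor substitution pattern with compound 1, so no single-change step between measured compounds is available.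

Compound 4 `COCc1ccc(Nc2nnc(Cc3c(Cl)cccc3Cl)o2)cc1` differs from compound 1 in one place: hydrogen in place of furan-3-yl on a saturated chain carbon bound to an oxygen on a saturated carbon. Nothing measured here shows what such a change does in this assay. The step from compound 1 to compound 4 is expected to be small, at most a modest rise, and may well sit within the scatter: a 1.2-fold higher number from compound 1 to compound 4 (0.08 log units; within the scatter). Compound 4 is therefore estimated at 25000 nM, with a range of 10000 nM to 60000 nM.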

Compound 4, half-maximal cytotoxic concentration: 100000 nM
Compound 4: middle estimate off by 4.0-fold (0.60 log units), on the low side; the measured number lies above the stated range.
By their numbers in this assay, from the lowest: compounds 3 and 2 (each within the scatter of the next); then compound 1; then compound 4.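

In this assay, within the data shown here, the furan-3-yl on this saturated chain carbon is no neutral passenger: hydrogen in its place gives a 4.8-fold higher number from compound 1 to compound 4 (0.68 log units; beyond the scatter) on the shared core, the first single-change step. The number therefore moves with this group alone, and the step lies beyond the scatter. No available data explain the size of this step.

Going by these compounds, whether a plain ethyl chain or an amine at this place would read like hydrogen or like furan-3-yl stays open. Also open, on these data alone, is whether the same change would move the number on the core of compound 2.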